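Adding Methoxy to Compound 1: What to Expect

This account rests on a few compounds, and the source may have more. Where it says the series, first, only, none or still open, it means among the compounds named here.

Compound 1, `CCCCNC(=O)NS(=O)(=O)c1ccc(-n2nc(-c3ccccc3)ccc2=O)cc1`, was tested in a functional assay on the whole organism (blood, strain Wistar albino) for inhibition, with Rattus norvegicus as the target, read by colorimetric assay, with stated times of 15 min and 90 min, at a dose of 20 mg/kg by the oral route (a higher number here means more inhibition at the dose given (going by the name of the read-out), a lower number less inhibition), where compound 1 gives 111%. This is the higher of the two numbers available. For the measured compounds named here, the only other measured compound, compound 2, `O=C(NC1CCCCC1)NS(=O)(=O)c1ccc(-n2nc(-c3ccccc3)ccc2=O)cc1`, gives 86.2% in this assay; the change between them, cyclohexyl in place of butyl on an amide-type nitrogen, brought a number 24.8 percentage points lower from compound 1 to compound 2 (beyond the scatter).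

Compound 3, `CCCCNC(=O)NS(=O)(=O)c1ccc(-n2nc(-c3ccc(OC)cc3)ccc2=O)cc1`, has not yet been measured. It differs from compound 1 in a different place: methoxy in place of hydrogen on an aromatic carbon. The new group sits on an aromatic carbon of a six-membered aromatic ring of carbon only, while the butyl chain on the amide-type nitrogen stays exactly as in compound 1. Going by the values given here, no measured step touches this ring, so the one known step, which concerns the nitrogen substituent, offers no direct guide. Without a comparable change to go by, the expectation is a step of no size beyond the scatter, namely a number 6 percentage points lower from compound 1 to compound 3 (within the scatter). Compound 3 is therefore estimated at 105%, with a plausible range from 85% to 120%.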

Compound 3, a percentage reported as inhibition, in the whole organism at one dose (the size of the read-out at that dose, not a potency): 25.6%
Beside the measured number, compound 3's estimate is 79.4 percentage points above it; measured number below the stated range.
By their numbers in this assay, from the lowest: compound 3; then compound 2; then compound 1.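

In this assay the change from phenyl to 4-methoxyphenyl gives a number 85.4 percentage points lower from compound 1 to compound 3 (beyond the scatter) and counts as a large step, so this ring position, para to a large group, is far from a silent part of the molecule. For the compounds shown here, until now the only known step lay on the amide-type nitrogen, where a number 24.8 percentage points lower from compound 1 to compound 2 (beyond the scatter) counts as modest, and the new step shows that adding just 2 heavy atoms on the aromatic ring can move the number further than that exchange of nitrogen substituents did. No information is available on what lies behind this drop, so the result records an effect without explaining it.

The compounds shown leave open whether any group at this position lowers the number or whether the drop is particular to methoxy, a question that a hydroxyl, a methyl or a fluorine in the same place would help to settle. They also leave open whether the same change would lower the number as far with the cyclohexyl group of compound 2 on the nitrogen in place of butyl.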